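Hydroxamic acid replaced by amine at the branch carbon

The source may report more compounds than this note shows. Statements on the series, on what has been measured and on what is new or still open speak of the compounds shown alone.

Compound 3 `CCCCC/C=C\C/C=C\C/C=C\C=C\C(CCCC(=O)O)CC(=O)NO` is the reference point for this step. For the measured compounds named here, in an assay for inhibition of Polyunsaturated fatty acid 5-lipoxygenase (Rattus norvegicus) (on this read-out higher numbers stand for weaker inhibition and lower numbers for stronger inhibition), compound 3 gives 190 nM, the lowest of the three numbers measured so far. Compound 1 `CCCCC/C=C\C/C=C\C/C=C\C=C\C(CS)CCCC(=O)O` gives 11000 nM in this assay, and compound 2 `CCCCC/C=C\C/C=C\C/C=C\C=C\C(CCCS)CCCC(=O)O` gives 36000 nM in this assay. The measured steps are a 58-fold lower number from compound 1 to compound 3 (1.76 log units; beyond the scatter) and a 190-fold lower number from compound 2 to compound 3 (2.28 log units; beyond the scatter), whereas the change between the two sulfur compounds is more modest, a 3.3-fold higher number from compound 1 to compound 2 (0.51 log units; beyond the scatter).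

Compound 4 `CCCCC/C=C\C/C=C\C/C=C\C=C\C(N)CCCC(=O)O` differs from compound 3 by amino in place of (hydroxycarbamoyl)methyl on a saturated chain carbon bound to a double-bonded chain carbon and a saturated chain carbon. Both large steps recorded in the series concern the hydroxycarbamoyl group entering; in compound 4 that group is gone and an amino group stands in its place, so the step from compound 3 to compound 4 reverses the direction of the steps from compound 1 and compound 2. Going by the values given here, the closest guide is compound 1, which carries a sulfanyl group in a comparable setting and gives 11000 nM; no amino analogue has been measured.

A large step toward a higher number in this assay is therefore expected, roughly a 63-fold higher number from compound 3 to compound 4 (1.80 log units; beyond the scatter), with compound 4 expected to land near the values of the sulfur compounds. The estimate for compound 4 in this assay is 12000 nM, with a range of 3000 nM to 50000 nM.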

Compound 4, half-maximal inhibitory concentration: 25000 nM
Estimate against measurement, compound 4: 2.1-fold (0.32 log units) below; the measured number falls inside the stated range.
By their numbers in this assay, from the lowest: compound 3; then compound 1; then compounds 4 and 2 (each within the scatter of the next).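

In this assay, amino in place of (hydroxycarbamoyl)methyl on this saturated chain carbon gives a 130-fold higher number from compound 3 to compound 4 (2.12 log units; beyond the scatter), so the low number of compound 3 does not carry over to a small nitrogen group placed directly on that carbon. Against the sulfur compounds, the amino group gives a 1.4-fold lower number from compound 2 to compound 4 (0.16 log units; within the scatter) and a 2.3-fold higher number from compound 1 to compound 4 (0.36 log units; beyond the scatter), which places compound 4 with compound 1 and compound 2 in the high range, far from compound 3: among the four compounds, amino, sulfanylmethyl and 3-sulfanylpropyl all leave this read-out well above the number of the hydroxycarbamoyl compound, with only a modest spread among themselves. No measured data here account for these differences.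

The compounds shown leave open whether the low number of compound 3 depends on the whole hydroxycarbamoyl group or on only part of it, a question that a carboxymethyl or carbamoylmethyl group at this carbon would address. They also leave open whether amino behaves differently at a distance from this carbon, as an aminomethyl or 3-aminopropyl group would show alongside the two sulfur compounds.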